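The source may hold more compounds than are shown below. What is called first, only, known or untested is meant among the compounds shown, and "the series" means these compounds.

Measured so far in an ADME assay (liver, Mus musculus) for metabolic stability, using microsomes; a lower number here means that the compound disappears faster, a higher number that the compound lasts longer:
- compound 1 `CCCc1nc2ccccn2c1C(=O)NCc1ccc(-c2ccccc2)cc1` gives 0.145 h here
- compound 2 `CCc1nc2cc(Cl)ccn2c1C(=O)NCc1ccc(N2CCCCC2)cc1` gives 0.0383 h here

Compound 2 has the lower of these two numbers, and its gap to compound 1 lies beyond the scatter of repeat measurements. Compound 3 `CCc1nc2cc(Cl)ccn2c1C(=O)NCc1ccc(-n2cc3c(c2)CCCC3)cc1` differs from compound 2 in one place (a group of 9 heavy atoms (8 carbon, 1 nitrogen; one five-membered aromatic ring with 1 hetero atom, one six-membered non-aromatic ring of carbon only) in place of a group of 6 heavy atoms (5 carbon, 1 nitrogen; one six-membered non-aromatic ring with 1 hetero atom), on an aromatic carbon). On an aromatic carbon of a six-membered aromatic ring of carbon only, para to a large group, the piperidin-1-yl group gives way to a group with one five-membered aromatic ring and one six-membered non-aromatic ring of carbon only. Within the data shown here, no two measured compounds differ in just one place, so the data show nothing directly about this exchange in this assay. The expectation is therefore no step beyond the scatter, with an estimated 1.3-fold higher number from compound 2 to compound 3 (0.12 log units; within the scatter) and a slight lean upward. Compound 3 is expected to give 0.05 h (estimated range 0.02 h to 0.13 h).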

Compound 3, half-life: 1.04 h
Compound 3: the middle estimate sits 21-fold (1.32 log units) below what was measured, outside the stated range (above it).
By their numbers in this assay, from the lowest: compound 2; then compound 1; then compound 3.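

Swapping piperidin-1-yl for the group with a five-membered aromatic ring and a six-membered carbon ring, on an aromatic carbon para to a large group, gives a 27-fold higher number from compound 2 to compound 3 (1.43 log units; beyond the scatter) in this assay and is the first single-place change available in this series. This position therefore has a strong influence on the half-life, and the exchange can move the number far beyond the usual scatter of repeat measurements. Nothing available explains why this exchange has such a large effect.

From the compounds shown here alone, it remains open whether the five-membered aromatic ring alone, as in a plain pyrrol-1-yl group, would give a similar step, or whether the added carbon ring is also needed. Also open, going by these compounds, is how other groups at this place, such as morpholin-4-yl or dimethylamino, would compare with piperidin-1-yl.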